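The source may report more compounds than this note shows. Statements on the series, on what has been measured and on what is new or still open speak of the compounds shown alone.

Working notes on the series. Compound 1 `C#CC(C)OC(=O)c1ccc(C(CC)(CC)c2ccc(OCC(O)C(C)(C)C)c(C)c2)n1CC` gives 200 nM in an assay on HL-60 cells for agonist activity at vitamin D3 receptor (Homo sapiens), read by microscopy, with a stated time of 96 h; on this read-out higher numbers stand for an effect only at larger amounts of compound and lower numbers for an effect already at smaller amounts. Compound 2 `CCOC(=O)c1ccc(OC(=O)c2ccc(C(CC)(CC)c3ccc(OCC(=O)C(C)(C)C)c(C)c3)n2CC)cc1` gives 45600 nM in this assay, the highest of the two numbers recorded; compound 1 stands nearest to it at a lower number, and that gap lies beyond the scatter. Within the data shown here, compound 1 and compound 2 differ in more than one place, so no single step connects them and only their two values can be set side by side. Compound 3 `CCOC(=O)c1ccc(OC(=O)c2ccc(C(CC)(CC)c3ccc(OCC(O)C(C)(C)C)c(C)c3)n2CC)cc1` has not been measured. It differs from compound 2 by 1-hydroxy-2,2-dimethylpropyl in place of (tert-butyl)carbonyl on a saturated chain carbon bound to an oxygen on an aromatic ring, and with this change it carries the same 2-hydroxy-3,3-dimethylbutoxy chain as compound 1. A downward step well beyond the scatter is expected in this assay, because compound 1 with that chain gives 200 nM whereas compound 2 gives 45600 nM. For compound 3 the expected value in this assay is 800 nM, with a range from 100 nM to 8000 nM, which means an estimated step of a 57-fold lower number from compound 2 to compound 3 (1.76 log units; beyond the scatter).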

Compound 3, half-maximal effective concentration: > 50000 nM
Compound 3 was reported as a limit; the forecaster's own chance of this, stated with the estimate: 5%; at least 62-fold (1.79 log units) between middle value and limit.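

Compound 3 gives a limit and not a number in this assay: the limit of > 50000 nM in this assay, at which 1 of the 3 values shown sits.

With 4-(ethoxycarbonyl)phenyl held on the ester oxygen, 1-hydroxy-2,2-dimethylpropyl in place of (tert-butyl)carbonyl gives an at least 1.0-fold higher number from compound 2 to compound 3 (0.04 log units; that floor lies within the scatter), so the 2-hydroxy-3,3-dimethylbutoxy chain alone does not bring a low number here. With that chain held, 4-(ethoxycarbonyl)phenyl in place of 1-methylprop-2-yn-1-yl on an oxygen next to a carbonyl group gives an at least 250-fold higher number from compound 1 to compound 3 (2.39 log units; beyond the scatter), which places the large difference at the ester rather than at the chain.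

As far as these compounds go, how (tert-butyl)carbonyl and 1-hydroxy-2,2-dimethylpropyl compare when 1-methylprop-2-yn-1-yl is held on the ester oxygen stays open. Also open, from the compounds shown here alone, is how a plain ethyl ester or a free carboxylic acid at that carbonyl would read in this assay.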